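A Hydroxy Group in Place of Bromomethyl

A few compounds are considered here, and "the series" means these few. Any claim that something is new, unique, unknown or untested is made for them only; others in the source may bear on it.

Going by the values given here, in a functional assay on U-937 cells (Homo sapiens) for cytotoxicity, read by MTT assay, with a stated time of 24 h (a lower number here means a stronger inhibitor, a higher number a weaker inhibitor), only two numbers are known so far. Compound 1 `BrCCCCOc1c(Br)cc(Br)cc1Oc1ccc(Br)cc1Br` gives 29 ug/mL and compound 2 `Brc1ccc(Oc2cc(Br)cc(Br)c2OCCCCCN2CCN(c3ccccc3)CC2)c(Br)c1` gives 42.5 ug/mL, so the two lie within the scatter of each other. Compound 3 `OCCCOc1c(Br)cc(Br)cc1Oc1ccc(Br)cc1Br` has not yet been measured. It departs from compound 1 by a single change, hydroxy in place of bromomethyl on a saturated chain carbon, three bonds along the chain from an oxygen on an aromatic ring. The same difference can be read as 4-bromobutyl to 3-hydroxypropyl. Among the compounds with values here, no measured step shows what such a change does in this assay, so the data favour no direction and no shift beyond the scatter is expected. Within the data shown here, the only guide is the level set by compound 1 at 29 ug/mL and compound 2 at 42.5 ug/mL. The expected 1.1-fold higher number from compound 1 to compound 3 (0.04 log units; within the scatter) is estimated to stay within the scatter. Compound 3 is expected at 32 ug/mL, with an estimated range of 13 ug/mL to 80 ug/mL.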

Compound 3, half-maximal inhibitory concentration: 32.3 ug/mL
For compound 3 the middle estimate is 1.0-fold (0.00 log units) below the measured one, and the stated range covers the measured number.
By their numbers in this assay, from the lowest: compounds 1, 3 and 2 (each within the scatter of the next).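

In this assay, putting hydroxy in place of bromomethyl on a saturated chain carbon, three bonds along the chain from an oxygen on an aromatic ring, gives a 1.1-fold higher number from compound 1 to compound 3 (0.05 log units; within the scatter) and leaves the two compounds within the scatter of each other. Going by these compounds alone, this is the first single-place step at this position, and it shows that going from 4-bromobutyl to 3-hydroxypropyl, which removes the bromine and adds a hydrogen-bond donor, moves the number by no more than the scatter in this read-out. No measurement at hand bears on why the two numbers stay so close.

Going by these compounds, whether a carboxylic acid or a primary amine at the chain end would keep the number at this level remains open, as does the effect of a longer chain ending in hydroxy. One step also cannot show whether the same exchange would read alike on another core.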